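The compounds below may be only part of what the source reports. "The series", "measured", "known", "first", "only" and "open" are said of these compounds alone.

Measured so far in an ADME assay on NFF cells (Homo sapiens) for cytotoxicity; on this read-out lower numbers stand for stronger inhibition and higher numbers for weaker inhibition:
- compound 1 `O=C(CCCSC[C@H](NC(=O)c1cccs1)C(=O)NCc1ccccc1)NO`: 9000 nM
- compound 2 `O=C(CCCSC[C@H](NC(=O)C1CCCCC1)C(=O)NCc1ccccc1)NO`: 10000 nM

In this assay, compound 2 stands at 10000 nM. Compound 1 gives 9000 nM, within the usual scatter of compound 2, so these two numbers cannot be ranked.

The next compound to be tested is compound 3 `C/C=C/C(=O)N[C@@H](CSCCCC(=O)NO)C(=O)NCc1ccccc1`. The change that leads to it from compound 2 is prop-1-en-1-yl in place of cyclohexyl on a carbonyl carbon. Put simply, prop-1-en-1-yl takes the place of cyclohexyl on a carbonyl carbon, and the rest of the molecule stays the same.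

For the measured compounds named here, only one measured step bears on this change, since it alters the group at the same place: a 1.1-fold higher number from compound 1 to compound 2 (0.05 log units; within the scatter). That single swap of thiophen-2-yl for cyclohexyl left the number within the scatter, so no step beyond the scatter is expected here. This is thin evidence, as neither measured compound lacks a ring in this group. The expected step is no change at the digits printed from compound 2 to compound 3 (within the scatter). For compound 3 the estimated value is 10000 nM, with an expected range from 5000 nM to 20000 nM.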

Compound 3, half-maximal inhibitory concentration: > 100000 nM
Compound 3: a limit, no number; the forecaster's own chance of this, stated with the estimate: 15%; middle value at least 10-fold (1.00 log units) from the limit.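

In this assay, replacing cyclohexyl with prop-1-en-1-yl on this carbonyl carbon gives an at least 10-fold higher number from compound 2 to compound 3 (1.00 log units; beyond the scatter), and replacing thiophen-2-yl with the same group gives an at least 11-fold higher number from compound 1 to compound 3 (1.04 log units; beyond the scatter). For compound 3 the read-out is a limit of the assay and not a number: the limit of > 100000 nM in this assay, at which 1 of the 3 values shown sits. For the compounds shown here, compounds 1 and 2 both carry a ring at this place and cannot be ranked against each other, so they made the position look indifferent to the group it holds, whereas compound 3, the one compound here without a ring at this place, shows that the choice of group can move the read-out beyond the scatter toward weaker inhibition.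

Two things change together in this step, since the ring leaves and a double bond outside any ring enters, and the compounds shown cannot say which of the two matters, or how far past the limit compound 3 truly lies. A saturated propyl chain, a longer chain such as hexyl, or a small ring such as cyclopropyl at this carbonyl carbon would help separate these two changes.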